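Fluoro to Chloro: What to Expect for Compound 4

The source may hold more compounds than are shown below. What is called first, only, known or untested is meant among the compounds shown, and "the series" means these compounds.

In a functional assay on A549 cells (Homo sapiens) for cytotoxicity, read by MTT assay, with a stated time of 72 h (a higher number here means a weaker inhibitor, a lower number a stronger inhibitor), the three measured compounds gave:
compound 1 `O=C(Nc1nc2ccccc2s1)c1cn(-c2ccccc2)nc1-c1ccc(F)cc1`: 9010 nM
compound 2 `O=C(Nc1nc2ccc(F)cc2s1)c1cn(-c2ccccc2)nc1-c1ccc(F)cc1`: 6650 nM
compound 3 `Cc1ccc2nc(NC(=O)c3cn(-c4ccccc4)nc3-c3ccc(F)cc3)sc2c1`: 24600 nM

Compound 3 gives the highest number of the three and is therefore the weakest inhibitor here: a 2.7-fold higher number from compound 1 to compound 3 (0.44 log units; beyond the scatter) and a 3.7-fold higher number from compound 2 to compound 3 (0.57 log units; beyond the scatter) both lie beyond the scatter, whereas a 1.4-fold lower number from compound 1 to compound 2 (0.13 log units; within the scatter) does not. Compound 4 `Cc1ccc2nc(NC(=O)c3cn(-c4ccccc4)nc3-c3ccc(Cl)cc3)sc2c1` differs from compound 3 in one place: chloro in place of fluoro on an aromatic carbon. For the measured compounds named here, none of the measured steps touches this position; all three concern a different part of the shared core, so no measured step bears directly on this change. Lacking such a precedent, no shift beyond the scatter is expected in this assay. Compound 4 is therefore expected to give about 22000 nM, with a range from 9000 nM to 55000 nM. This amounts to an expected 1.1-fold lower number from compound 3 to compound 4 (0.05 log units; within the scatter).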

Compound 4, half-maximal inhibitory concentration: 18600 nM
Compound 4: the middle estimate sits 1.2-fold (0.07 log units) above what was measured; the range from low to high includes it.
By their numbers in this assay, from the lowest: compounds 2 and 1 (each within the scatter of the next); then compounds 4 and 3 (each within the scatter of the next).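

Changing the 4-fluorophenyl to a 4-chlorophenyl gives the first measured result at this position. In this assay the change brings a 1.3-fold lower number from compound 3 to compound 4 (0.12 log units; within the scatter) and so leaves the number effectively unchanged, at least with the methyl-bearing compound 3 as the starting point. No available evidence explains this result.

The compounds shown leave open whether a group other than a halogen, such as an amine, a methoxy group or a carboxylic acid, would shift the number at this position. They also leave open whether the same exchange would behave alike on compound 1 or compound 2.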